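Urea series: substituent change on the aromatic carbon

The source may report more compounds than this note shows. Statements on the series, on what has been measured and on what is new or still open speak of the compounds shown alone.

Measured so far:
compound 1, `Cc1ccccc1NC(=O)N[C@H](C)c1ccccc1`, 100% in an ADME assay on the whole organism with Oryza sativa as the target, tested at 0.1 uM; a lower number here means a stronger effect, a higher number a weaker effect of the compound at the concentration tested
compound 2, `CC(=O)c1ccccc1NC(=O)N[C@H](C)c1ccccc1`, 96%

Compound 2 stands lowest of the two numbers measured; its nearest neighbour is compound 1, and the step of a number 4 percentage points lower from compound 1 to compound 2 (within the scatter) was within the scatter, so the two values are to be read as alike rather than ordered.

The next compound, compound 3, `C[C@@H](NC(=O)Nc1ccccc1Br)c1ccccc1`, is not yet measured. It differs from compound 2 in one place: bromo in place of acetyl on an aromatic carbon. The change sits on an aromatic carbon of a six-membered aromatic ring of carbon only, ortho to a large group.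

Among the compounds with values here, only one measured step bears on this position, a number 4 percentage points lower from compound 1 to compound 2 (within the scatter), and it was within the scatter. Within the data shown here, no step with a bromo group is known at all, so nothing in the measured pairs points to a change beyond the scatter in either direction. The working expectation is therefore that compound 3 stays near compound 2, with an estimated step of a number 1 percentage points higher from compound 2 to compound 3 (within the scatter).

For compound 3 the estimate is 97%, with a range from 85% to 100%.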

Compound 3, a percentage reported as activity, at one concentration (the size of the read-out at that concentration, not a potency): 99%
Compound 3: the middle estimate sits 2 percentage points below what was measured, within the range that was stated.
By their numbers in this assay, from the lowest: compounds 2, 3 and 1 (each within the scatter of the next).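

In this assay, the step is a number 3 percentage points higher from compound 2 to compound 3 (within the scatter), and the comparison with the first compound gives a number 1 percentage points lower from compound 1 to compound 3 (within the scatter), so methyl, acetyl and bromo on this aromatic carbon, ortho to a large group, cannot be told apart among compounds 1, 2 and 3. Within the data shown here, the exchange is also a larger one than the first step alone could test: acetyl, with 3 heavy atoms and 1 hydrogen-bond acceptor, gives way to bromo, with 1 heavy atom and 0 hydrogen-bond acceptors, and the values stay alike, with no compound of the three going against this. No supporting measurement is available to explain this likeness.

On these data alone, it remains open whether any group at this position can move the number beyond the scatter, since an amine, a carboxylic acid or a longer chain on the same aromatic carbon would test the position with groups unlike these three. The compounds shown also leave open whether the same likeness would hold with these groups on another carbon of the ring, or with a different group in place of the methyl on the chiral carbon of the shared core.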